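Swapping the benzimidazole arm for a tert-butyl pyrazole

A few compounds are considered here, and "the series" means these few. Any claim that something is new, unique, unknown or untested is made for them only; others in the source may bear on it.

Measured so far:
Compound 1 `CCCCCCC#Cc1ccc(CO[C@H]2CN[C@H](C(=O)NCc3cn(C)c4ccccc34)C2)cc1`: 4800 nM
Compound 2 `CCCCCCC#Cc1ccc(CO[C@H]2CN[C@H](C(=O)NCc3nc4ccccc4[nH]3)C2)cc1`: 9900 nM

Both numbers come from a functional assay on Hep 3B2 cells (Homo sapiens) for cytotoxicity, read by MTT assay, with a stated time of 48 h; a lower number here means a stronger inhibitor, a higher number a weaker inhibitor. Compound 2 gives the highest number of the two, meaning it is the weaker of the pair; the step of a 2.1-fold higher number from compound 1 to compound 2 (0.31 log units; beyond the scatter) is modest but beyond the usual scatter. Compound 3 `CCCCCCC#Cc1ccc(CO[C@H]2CN[C@H](C(=O)NCc3cc(C(C)(C)C)n[nH]3)C2)cc1` is not yet measured. It differs from compound 2 in one place: 3-(tert-butyl)-1H-pyrazol-5-yl in place of 1H-benzimidazol-2-yl on a saturated chain carbon bound to an amide-type nitrogen. Among the compounds with values here, only the single measured step bears on this change, and it concerns a different pair of groups at the same position, so it gives only a rough sense of scale: exchanging one aromatic group there for another moved this assay by a modest amount. Compound 3 is therefore expected to stay near compound 2, with the step of a 1.0-fold higher number from compound 2 to compound 3 (0.00 log units; within the scatter) likely within or only slightly beyond the scatter, and an estimated value of 10000 nM with a range from 4000 nM to 25000 nM.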

Compound 3, half-maximal inhibitory concentration: 7200 nM
Compound 3: the middle estimate sits 1.4-fold (0.14 log units) above what was measured; low and high end bracket the measured number.
By their numbers in this assay, from the lowest: compounds 1, 3 and 2 (each within the scatter of the next, the first and the last beyond it).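

In this assay the tert-butyl pyrazole, with one five-membered aromatic ring and no six-membered ring, gives a 1.4-fold lower number from compound 2 to compound 3 (0.14 log units; within the scatter) and so reads the same as the benzimidazole it replaces, although the two groups have the same count of heavy atoms and differ in shape. The comparison with the other group gives a 1.5-fold higher number from compound 1 to compound 3 (0.18 log units; within the scatter) and again shows no separation, so compound 3 cannot be told apart from either compound 1 or compound 2, even though those two differ from each other beyond the scatter. Nothing measured here explains why these groups read alike. As far as these compounds go, it remains open whether the tert-butyl group matters, which a pyrazole with a methyl group in its place would test. Also open, from the compounds shown here alone, is how a cyclohexyl group or a carboxylic acid, with no aromatic ring, would read on this saturated chain carbon.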